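Carbamoylpiperazine in Place of Piperidine: Expected Microsomal Stability

This account rests on a few compounds, and the source may have more. Where it says the series, first, only, none or still open, it means among the compounds named here.

Compound 2 `c1ccc2c(c1)CN[C@@H](CN(CC[C@@H]1CCCNC1)[C@H]1CCCc3cccnc31)C2` holds the larger of the two numbers in an ADME assay on microsomes from liver (Homo sapiens) for metabolic stability, read by LC-MS, with a stated time of 10 min, tested at 0.5 uM (a higher number here means that more of the compound is left, a lower number that less of the compound is left), where compound 2 gives 75%. Compound 1 `CN1CCN(CCCN(C[C@H]2Cc3ccccc3CN2)[C@H]2CCCc3cccnc32)CC1` gives 72%, and the step of a number 3 percentage points higher from compound 1 to compound 2 (within the scatter) lies within the scatter. Compound 3 `NC(=O)N1CCN(CCCN(C[C@H]2Cc3ccccc3CN2)[C@H]2CCCc3cccnc32)CC1` differs from compound 2 in one place: (4-carbamoylpiperazin-1-yl)methyl in place of piperidin-3-yl on a saturated chain carbon, two bonds along the chain from an amine nitrogen. Among the measured compounds shown here, the only measured step bearing on this change is that from compound 1 to compound 2, which was small, so no step beyond the scatter is expected in this assay. Compound 3 is therefore estimated at 74%, between 60% and 86%, an expected step of a number 1 percentage points lower from compound 2 to compound 3 (within the scatter).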

Compound 3, percent of the compound remaining: 79%
Compound 3: the middle estimate sits 5 percentage points below what was measured, within the range that was stated.
By their numbers in this assay, from the lowest: compounds 1, 2 and 3 (each within the scatter of the next).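

In this assay, (4-carbamoylpiperazin-1-yl)methyl in place of piperidin-3-yl gives a number 4 percentage points higher from compound 2 to compound 3 (within the scatter) and so, like the earlier change at this place, stays within the scatter. Carbamoyl in place of methyl on the ring amine nitrogen gives a number 7 percentage points higher from compound 1 to compound 3 (within the scatter) and adds a second change that stays within the scatter, this time on that nitrogen. No evidence on the cause accompanies these results. From the compounds shown here alone, whether an acetyl group or a carboxylic acid on that nitrogen would move the number beyond the scatter stays open, as does the effect of a longer chain.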